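Moving the ether oxygen along the ester side chain

The source may hold more compounds than are shown below. What is called first, only, known or untested is meant among the compounds shown, and "the series" means these compounds.

Measured compounds:
- compound 1, `C=C(C)CCOC(=O)C1=C(C)NC(C)=C(C(=O)OC)C1c1cccc([N+](=O)[O-])c1`, 47 nM
- compound 2, `COC(=O)C1=C(C)NC(C)=C(C(=O)OCc2cc([N+](=O)[O-])cc([N+](=O)[O-])c2)C1c1cccc([N+](=O)[O-])c1`, 40 nM
- compound 3, `COC(=O)C1=C(C)NC(C)=C(C(=O)OCCOCc2ccccc2)C1c1cccc([N+](=O)[O-])c1`, 12 nM

All three share the same core and differ only in the ester side chain. In a functional assay on HEK293 cells for antagonist activity at Voltage-dependent L-type calcium channel subunit alpha-1D (Rattus norvegicus), read by FLIPR (a lower number here means a stronger inhibitor, a higher number a weaker inhibitor), compound 3 gives the lowest number of the three and is the strongest inhibitor here: the steps of a 3.9-fold lower number from compound 1 to compound 3 (0.59 log units; beyond the scatter) and a 3.3-fold lower number from compound 2 to compound 3 (0.52 log units; beyond the scatter) are both modest but beyond the scatter, while the step of a 1.2-fold lower number from compound 1 to compound 2 (0.07 log units; within the scatter) is within it.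

Compound 4, `COC(=O)C1=C(C)NC(C)=C(C(=O)OCCCOc2ccccc2)C1c1cccc([N+](=O)[O-])c1`, keeps every atom of compound 3 but joins them differently: phenoxymethyl in place of benzyloxy on a saturated chain carbon, two bonds along the chain from an oxygen next to a carbonyl group. Going by the values given here, no measured step tests such a rearrangement of the same atoms; the two informative steps only show that the side chain of compound 3 gave a modest gain over those of compounds 1 and 2. With the same atoms retained, the expectation for compound 4 is a number close to that of compound 3, with the step of a 1.3-fold higher number from compound 3 to compound 4 (0.12 log units; within the scatter) estimated to stay within the scatter. Compound 4 is therefore expected at about 16 nM, in a range from 6 nM to 45 nM.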

Compound 4, half-maximal inhibitory concentration: 11 nM
Compound 4: middle estimate off by 1.5-fold (0.16 log units), on the high side; measured number inside the range.
By their numbers in this assay, from the lowest: compounds 4 and 3 (each within the scatter of the next); then compounds 2 and 1 (each within the scatter of the next).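

The change from 2-(benzyloxy)ethyl to 3-phenoxypropyl moves the ether oxygen along the side chain and gives, in this assay, a 1.1-fold lower number from compound 3 to compound 4 (0.04 log units; within the scatter), so these two side chains cannot be told apart here. The advantage over the two shorter-named side chains therefore does not depend on this one placement of the oxygen, with a 3.6-fold lower number from compound 2 to compound 4 (0.56 log units; beyond the scatter) and a 4.3-fold lower number from compound 1 to compound 4 (0.63 log units; beyond the scatter), both modest but beyond the scatter. The data shown offer no explanation for this result.

From the compounds shown here alone, whether the ether oxygen is needed at all remains open, and a plain carbon chain such as 4-phenylbutyl in its place would address that. Also open, going by these compounds, is how an amine in place of that oxygen, or a longer chain between the ester and the phenyl ring, would read in this assay.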